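The source may hold more compounds than are shown below. What is called first, only, known or untested is meant among the compounds shown, and "the series" means these compounds.

Measured compounds in a functional assay on MCF7 cells (Homo sapiens) for cytotoxicity, read by colorimetric assay and MTT assay; on this read-out higher numbers stand for weaker inhibition and lower numbers for stronger inhibition:
- compound 1 `COc1ccc(-c2cc3c(OC)cc(OC)cc3n(C)c2=O)cc1`: 10000 nM
- compound 2 `CCOC(=O)Cn1c(=O)c(-c2ccc(OC)cc2)cc2c(OC)cc(OC)cc21`: 10000 nM
- compound 3 `COc1ccc(-c2cc3c(OC)cc(OC)cc3n(CC#N)c2=O)cc1`: 10000 nM

The three measured compounds share one core and differ only in the group on the saturated chain carbon bound to the aromatic nitrogen. In this assay compound 3 gives 10000 nM and stands level with compound 1 and compound 2. The steps among them carry no movement: no change at the digits printed from compound 1 to compound 2 (within the scatter), no change at the digits printed from compound 1 to compound 3 (within the scatter) and no change at the digits printed from compound 2 to compound 3 (within the scatter), all within the scatter.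

Compound 4 `COc1ccc(-c2cc3c(OC)cc(OC)cc3n(CCCC#N)c2=O)cc1` is not yet measured. Its difference from compound 3 is 2-cyanoethyl in place of cyano on a saturated chain carbon bound to an aromatic nitrogen. The measured steps that bear on this place are the three above; each of them exchanged one substituent for another at the same carbon without a change beyond the scatter, whether hydrogen, ethoxycarbonyl or cyano stood there. Lengthening the group to 2-cyanoethyl is a further variation at the same position, and nothing in the series points to a direction, so no step beyond the scatter is expected in this assay: no change at the digits printed from compound 3 to compound 4 (within the scatter) is the expected step. For compound 4 the expected value in this assay is 10000 nM, with a range from 5000 nM to 20000 nM.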

Compound 4, half-maximal inhibitory concentration: 10000 nM
Compound 4: the middle estimate sits on the measured number at the digits printed; the measured number falls inside the stated range.
By their numbers in this assay, from the lowest: compounds 1, 2, 3 and 4 (each within the scatter of the next).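

Until now the nitrile at this place was seen only as cyanomethyl. With 3-cyanopropyl in its place, this assay shows no change at the digits printed from compound 3 to compound 4 (within the scatter), so the added chain carbons of the 2-cyanoethyl group do not separate these two nitrile compounds. The comparison with the other groups on this saturated chain carbon bound to an aromatic nitrogen reads the same, with no change at the digits printed from compound 2 to compound 4 (within the scatter) against ethoxycarbonyl and no change at the digits printed from compound 1 to compound 4 (within the scatter) against hydrogen, and the four compounds now stand at one level whatever their group; nothing available gives a reason for this flat result.

Open, on these data alone, is whether any group at this place can shift the value at all, for instance a primary amine, a carboxylic acid in place of the ethyl ester, or a chain ending in a phenyl ring. Open too, as far as these compounds go, is what a change on the shared core would do, as all four compounds carry it unaltered, so this series cannot say whether the core or the chain sets the level seen here.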